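The source may report more compounds than this note shows. Statements on the series, on what has been measured and on what is new or still open speak of the compounds shown alone.

Measured in a functional assay on HT-29 cells (Homo sapiens) for cytotoxicity, read by MTT assay, with a stated time of 72 h; on this read-out lower numbers stand for stronger inhibition of growth and higher numbers for weaker inhibition of growth:

Compound 1 `C[Se]/C(=N\C(=O)c1cccs1)NC(=O)c1cccs1` — compound 1 gives 0.34 nM.
Compound 2 `CS/C(=N\C(=O)c1cccs1)NC(=O)c1cccs1` — compound 2 gives 77900 nM.
Compound 3 `CS/C(=N\C(=O)c1cc(-c2ccccc2)nc2ccccc12)NC(=O)c1cc(-c2ccccc2)nc2ccccc12` — compound 3 gives 23700 nM.

Compound 1 and compound 2 share one core and differ only by a group of 2 heavy atoms (1 carbon, 1 selenium; no ring) in place of a group of 2 heavy atoms (1 carbon, 1 sulfur; no ring), on a carbon with a double bond to nitrogen. Among the measured compounds shown here, that change gives a 230000-fold lower number from compound 2 to compound 1 (5.36 log units; beyond the scatter), the one large step seen so far. For the measured compounds named here, compound 3 carries a different core; how its core differs from that of compound 2 is not broken down here, and the two values show only that compound 3 sits somewhat lower than compound 2.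

Compound 4 `C[Se]/C(=N\C(=O)c1cc(-c2ccccc2)nc2ccccc12)NC(=O)c1cc(-c2ccccc2)nc2ccccc12` is not yet measured. Going by the values given here, compound 4 differs from compound 3 by a group of 2 heavy atoms (1 carbon, 1 selenium; no ring) in place of a group of 2 heavy atoms (1 carbon, 1 sulfur; no ring), on a carbon with a double bond to nitrogen, the same kind of change as the one from compound 2 to compound 1, made on the core of compound 3 rather than that of compound 2.

As far as these compounds go, for compound 4 a large downward step of the same kind is expected, estimated as a 24000-fold lower number from compound 3 to compound 4 (4.37 log units; beyond the scatter), resting on the step of a 230000-fold lower number from compound 2 to compound 1 (5.36 log units; beyond the scatter) seen on the other core, with wide uncertainty because the core-to-core transfer of that step is untested. Compound 4 is therefore estimated at 1 nM in this assay, expected between 0.05 nM and 30 nM.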

Compound 4, concentration for 50% growth inhibition: 460 nM
Compound 4: middle estimate off by 460-fold (2.66 log units), on the low side, and the stated range ends below it.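

In this assay, putting the selenium-bearing group in place of methylsulfanyl, on a carbon with a double bond to nitrogen, again gives a large downward step, a 52-fold lower number from compound 3 to compound 4 (1.71 log units; beyond the scatter), so the direction of the change carries over to the core of compound 3. The size of the step does not carry over: the same change on two cores in this assay, a 230000-fold lower number (5.36 log units; beyond the scatter) from compound 2 to compound 1 and a 52-fold lower number (1.71 log units; beyond the scatter) from compound 3 to compound 4, 4400-fold (3.65 log units) apart, beyond the scatter of two such steps These two cores show that the step's size depends on the core it is made on, but they do not show which feature of the core sets that size, and they give no rule for predicting the step on a further core.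

Still open, as far as these compounds go, is how the step behaves when the methyl on sulfur or selenium gives way to a longer chain such as ethyl, or when either core carries an amine or a carboxylic acid. Also open, from the compounds shown here alone, is whether the same gap between the two cores appears in any other cell assay.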